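The compounds below may be only part of what the source reports. "The series", "measured", "known", "first", "only" and "open" are said of these compounds alone.

Measured compounds on an assay on isolated protein for inhibition of glutathione S-transferase P (Homo sapiens), with a stated time of 10 min; on this read-out lower numbers stand for stronger inhibition and higher numbers for weaker inhibition:
- compound 1 `COc1ccccc1NC(=O)CCC(=O)OCCCCCCSc1ccc([N+](=O)[O-])c2nonc12`: compound 1 gives 4050 nM
- compound 2 `O=C(CCC(=O)OCCCCCCSc1ccc([N+](=O)[O-])c2nonc12)Nc1cccc(Cl)c1`: compound 2 gives 28800 nM
- compound 3 `O=C(CCC(=O)OCCCCCCSc1ccc([N+](=O)[O-])c2nonc12)Nc1ccc(C(F)(F)F)cc1`: compound 3 gives 5050 nM

Compound 3 sits second highest of the three numbers on this assay; compound 1 is nearest, with the gap between them inside the scatter, and compound 2 is furthest, with a 5.7-fold lower number from compound 2 to compound 3 (0.76 log units; beyond the scatter). Going by the values given here, the only steps here all swap the aryl group on the amide-type nitrogen: a 1.2-fold higher number from compound 1 to compound 3 (0.10 log units; within the scatter) is within the scatter, while a 7.1-fold higher number from compound 1 to compound 2 (0.85 log units; beyond the scatter) and a 5.7-fold lower number from compound 2 to compound 3 (0.76 log units; beyond the scatter) are beyond it, both placing the 3-chlorophenyl compound at the high end.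

Compound 4 `O=C(CCC(=O)OCCCCCCSc1ccc([N+](=O)[O-])c2nonc12)Nc1ccc(F)c(Cl)c1` differs from compound 3 by 3-chloro-4-fluorophenyl in place of 4-(trifluoromethyl)phenyl on an amide-type nitrogen. The entering group carries the 3-chloro substitution seen in compound 2, which gave 28800 nM, plus a fluorine. The step from compound 2 to compound 3 bears most directly, so the number for compound 4 is expected to move back up, but not fully to compound 2, giving an estimated step of a 2.4-fold higher number from compound 3 to compound 4 (0.38 log units; beyond the scatter). Compound 4 is thus estimated at 12000 nM, with a range of 4000 nM to 36000 nM.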

Compound 4, half-maximal inhibitory concentration: 9850 nM
Compound 4: the middle estimate sits 1.2-fold (0.09 log units) above what was measured; measured number inside the range.
By their numbers in this assay, from the lowest: compounds 1, 3 and 4 (each within the scatter of the next, the first and the last beyond it); then compound 2.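

In this assay, going by these compounds alone, fluoro in place of hydrogen on an aromatic carbon gives a 2.9-fold lower number from compound 2 to compound 4 (0.47 log units; beyond the scatter), the first single-atom change, so the number of compound 2 is not fixed by the 3-chloro substitution alone. The 3-chloro-4-fluorophenyl group gives a 2.0-fold higher number from compound 3 to compound 4 (0.29 log units; within the scatter), which stays within the scatter, and a 2.4-fold higher number from compound 1 to compound 4 (0.39 log units; beyond the scatter), which lies beyond it, even though compound 1 and compound 3 are within the scatter of each other. Nothing measured here explains either the fluoro step or these aryl comparisons.

Still open, going by these compounds, is whether fluoro on a phenyl group without chloro gives a step of similar size and direction. Also open, on these data alone, is how an amine or a carboxylic acid on the aryl group would compare with these halogen-bearing compounds.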